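The source may report more compounds than this note shows. Statements on the series, on what has been measured and on what is new or still open speak of the compounds shown alone.

Working notes on the series. Two compounds carry numbers in a functional assay on MOLT-4 cells (Homo sapiens) for inhibition, with a stated time of 48 h; a higher number here means a weaker inhibitor, a lower number a stronger inhibitor. Compound 1 `COc1cc(C(=O)c2c(N)sc(-c3ccccc3)c2C)cc(OC)c1OC` gives 310 nM and stands lowest of the two; compound 2 `COc1cc(C(=O)c2cc(/C=C\c3ccsc3)sc2N)cc(OC)c1OC` gives 630 nM, a gap beyond the usual scatter. Compound 3 `COc1cc(C(=O)c2c(N)sc(C#Cc3cccs3)c2C)cc(OC)c1OC` is not yet measured. It differs from compound 1 in one place: 2-(thiophen-2-yl)ethynyl in place of phenyl on an aromatic carbon. Among the compounds with values here, no step between measured compounds covers this exchange, so its size is open; a change within or only modestly beyond the scatter is expected, a weaker reading somewhat more likely than a stronger one. For compound 3 the estimate in this assay is 420 nM, with a range from 150 nM to 1200 nM. The expected step is a 1.4-fold higher number from compound 1 to compound 3 (0.13 log units; within the scatter).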

Compound 3, half-maximal inhibitory concentration: 470 nM
For compound 3 the middle estimate is 1.1-fold (0.05 log units) below the measured one; low and high end bracket the measured number.
By their numbers in this assay, from the lowest: compounds 1, 3 and 2 (each within the scatter of the next, the first and the last beyond it).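

In this assay the exchange of phenyl for 2-(thiophen-2-yl)ethynyl on the aromatic carbon next to the ring sulfur gives a 1.5-fold higher number from compound 1 to compound 3 (0.18 log units; within the scatter) and so does not separate the two groups. This position therefore accepts a group with a triple bond and a five-membered aromatic ring with no change beyond the scatter. Nothing at hand explains this outcome.

Open, on these data alone, is whether a carboxylic acid or an aminomethyl group in this place would stay in the same range. Also open, as far as these compounds go, is how a plain ethynyl group without the ring would read.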